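The source may report more compounds than this note shows. Statements on the series, on what has been measured and on what is new or still open speak of the compounds shown alone.

Measured so far, in an assay on isolated protein for displacement of a labelled ligand from metabotropic glutamate receptor 5 (Homo sapiens), with a stated time of 60 min, tested at 1 uM; a higher number here means more inhibition at the concentration tested (going by the name of the read-out), a lower number less inhibition:
- compound 1 `CC1CCN(c2c(S(=O)(=O)c3ccc(F)c(Cl)c3)cnc3cc(Cl)ccc23)CC1` gives 94%
- compound 2 `Cc1ccc(S(=O)(=O)c2cnc3cc(Cl)ccc3c2N2CCC(C)CC2)cc1` gives 94%
- compound 3 `CC1CCN(c2c(S(=O)(=O)c3cccc(C#N)c3)cnc3cc(Cl)ccc23)CC1` gives 94%

Compound 3 stands level with compounds 1 and 2 on these numbers. Compound 4 `CC1CCN(c2c(S(=O)(=O)c3cc(Cl)cc(Cl)c3)cnc3cc(Cl)ccc23)CC1` differs from compound 3 only on the sulfonyl sulfur: 3,5-dichlorophenyl in place of 3-cyanophenyl on a sulfonyl sulfur. Three earlier steps alter the same group on the same sulfonyl sulfur, and each leaves the inhibition where it was: no change at the digits printed from compound 1 to compound 2 (within the scatter), no change at the digits printed from compound 1 to compound 3 (within the scatter) and no change at the digits printed from compound 2 to compound 3 (within the scatter). Every variation of this group seen so far has therefore stayed within the scatter. On that basis the expected step is a number 2 percentage points lower from compound 3 to compound 4 (within the scatter), with no movement beyond the scatter in either direction. Compound 4 is estimated at 92%, with a likely range from 80% to 100%.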

Compound 4, a percentage reported as inhibition, at one concentration (the size of the read-out at that concentration, not a potency): 93%
Compound 4: the middle estimate sits 1 percentage points below what was measured; the measured number falls inside the stated range.
By their numbers in this assay, from the lowest: compounds 4, 1, 2 and 3 (each within the scatter of the next).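

In this assay, the change to 3,5-dichlorophenyl on the sulfonyl sulfur stays within the scatter against each earlier group, giving a number 1 percentage points lower from compound 3 to compound 4 (within the scatter), a number 1 percentage points lower from compound 2 to compound 4 (within the scatter) and a number 1 percentage points lower from compound 1 to compound 4 (within the scatter). Across these four compounds, a dichlorinated phenyl therefore joins the chloro-fluoro, methyl and cyano phenyl groups at the same level of inhibition. No supporting evidence bears on this result. The compounds shown leave open whether a saturated ring such as cyclohexyl, or a phenyl bearing a carboxylic acid, would hold this level on the sulfonyl sulfur. They also leave open whether these four compounds would separate at a lower concentration.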